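Trimming the sulfonamide chain in a kinase inhibitor series

A few compounds are considered here, and "the series" means these few. Any claim that something is new, unique, unknown or untested is made for them only; others in the source may bear on it.

Compound 1, `CCCNS(=O)(=O)c1ccc(Nc2ncc3c(n2)N(C2CCCC2)[C@H](CC)C(=O)N3C)cc1`, gives 17.8 nM in an assay for inhibition of serine/threonine-protein kinase PLK2 (Homo sapiens), read by FRET and Z'-LYTE, with a stated time of 1 h; on this read-out lower numbers stand for stronger inhibition and higher numbers for weaker inhibition.
Compound 2, `CC[C@@H]1C(=O)N(C)c2cnc(Nc3ccc(S(=O)(=O)NCCCO)cc3)nc2N1C1CCCC1`, gives 8.16 nM in this assay.

For the measured compounds named here, compound 2 stands at the lower of the two numbers measured so far, with compound 1 the nearest; the single step between them, a 2.2-fold lower number from compound 1 to compound 2 (0.34 log units; beyond the scatter), lies beyond the scatter. Compound 3, `CC[C@@H]1C(=O)N(C)c2cnc(Nc3ccc(S(N)(=O)=O)cc3)nc2N1C1CCCC1`, is not yet measured in this assay. It differs from compound 2 by hydrogen in place of 3-hydroxypropyl on a sulfonamide nitrogen.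

Going by the values given here, only one measured step bears on this change: a 2.2-fold lower number from compound 1 to compound 2 (0.34 log units; beyond the scatter), in which adding the hydroxy at the end of the chain gave a modestly lower number. Compound 3 removes that hydroxy together with the chain that carries it, so the gain seen in that step is expected to be lost, while what the remaining chain carbons contribute is not shown by any measured pair. A modest rise in the number is therefore expected, a 1.8-fold higher number from compound 2 to compound 3 (0.26 log units; within the scatter), bringing it back toward the value of compound 1. Compound 3 is estimated at 15 nM in this assay, with a range from 5 nM to 45 nM.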

Compound 3, half-maximal inhibitory concentration: 10.2 nM
Compound 3: the middle estimate sits 1.5-fold (0.17 log units) above what was measured; low and high end bracket the measured number.
By their numbers in this assay, from the lowest: compounds 2, 3 and 1 (each within the scatter of the next, the first and the last beyond it).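

In this assay the sulfonamide nitrogen can lose its whole side chain and carry only hydrogen while the number stays in the same range: the change is a 1.3-fold higher number from compound 2 to compound 3 (0.10 log units; within the scatter) from the hydroxylated chain and a 1.7-fold lower number from compound 1 to compound 3 (0.24 log units; within the scatter) from the plain propyl chain. Only compound 1 and compound 2 lie beyond the scatter of each other, and compound 3 falls within the scatter of both, so the 3-hydroxypropyl group shows no clear gain over hydrogen and the propyl group shows no clear loss against it; the earlier pair alone could not show this, since it compared only two chains. Nothing available explains these numbers.

The compounds shown leave open whether any group on this nitrogen can move the number clearly away from that of hydrogen, in either direction. A longer chain, a chain ending in an amine or a carboxylic acid, or a single methyl on the nitrogen would each test this, and a chain bearing the hydroxy on a different carbon would show whether its place along the chain matters.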